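Benzylcarbonyl for cyano on a chromanol guanidine core

This account rests on a few compounds, and the source may have more. Where it says the series, first, only, none or still open, it means among the compounds named here.

Measured so far:
compound 1 `CC1(C)Oc2ccc(C#N)cc2[C@@H](/N=C(\NC#N)Nc2ccc(Cl)cc2)[C@@H]1O`: 1800 nM
compound 2 `CC1(C)Oc2ccc(C(=O)c3ccccc3)cc2[C@@H](/N=C(\NC#N)Nc2ccc(Cl)cc2)[C@@H]1O`: 7100 nM

Of the compounds shown here, two sharing one core have been measured in a functional assay (aorta) with Rattus norvegicus as the target; on this read-out lower numbers stand for stronger inhibition and higher numbers for weaker inhibition. Compound 1 gives 1800 nM and stands lowest of the two numbers; its nearest neighbour is compound 2, which gives 7100 nM. Among the compounds with values here, the single step between them, a 3.9-fold higher number from compound 1 to compound 2 (0.60 log units; beyond the scatter), replaces the cyano group with a benzoyl group on an aromatic carbon of the core.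

Compound 3 `CC1(C)Oc2ccc(C(=O)Cc3ccccc3)cc2[C@@H](/N=C(\NC#N)Nc2ccc(Cl)cc2)[C@@H]1O` has not yet been measured in this assay. It differs from compound 1 by benzylcarbonyl in place of cyano on an aromatic carbon. Within the data shown here, the only measured step that bears on this change is a 3.9-fold higher number from compound 1 to compound 2 (0.60 log units; beyond the scatter), where a group of comparable build, the benzoyl, took the place of the same cyano group at the same position and raised the number beyond the scatter. On that basis a step of similar direction and size, a 3.3-fold higher number from compound 1 to compound 3 (0.52 log units; beyond the scatter), is expected for compound 3, though nothing measured tells how the extra methylene of the benzylcarbonyl alters the outcome. Compound 3 is therefore estimated at 6000 nM, with a range from 2500 nM to 14000 nM.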

Compound 3, half-maximal inhibitory concentration: 6800 nM
Beside the measured number, compound 3's estimate is 1.1-fold (0.05 log units) below it, within the range that was stated.
By their numbers in this assay, from the lowest: compound 1; then compounds 3 and 2 (each within the scatter of the next).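

In this assay, a 3.8-fold higher number from compound 1 to compound 3 (0.58 log units; beyond the scatter) shows that the rise seen with benzoyl is not unique to that group, since benzylcarbonyl in place of cyano on this aromatic carbon also lands beyond the scatter of compound 1. Within the data shown here, the new compound also gives the first reading of the link between the carbonyl and the phenyl ring: with benzyl in place of phenyl on the carbonyl carbon, a 1.0-fold lower number from compound 2 to compound 3 (0.02 log units; within the scatter) leaves the two compounds indistinguishable in this read-out. Nothing measured here gives a reason for either result.

The compounds shown leave open whether the carbonyl or the phenyl ring goes with the higher numbers, a question that a plain acetyl group or a benzyl group without the carbonyl on the same aromatic carbon would address. They also leave open how a longer chain between the carbonyl and the phenyl ring would read, and whether an amine or a carboxylic acid at this carbon would stay nearer to compound 1 or to the two carbonyl compounds.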